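Chloro added to the anilino ring of a shared core

The source may report more compounds than this note shows. Statements on the series, on what has been measured and on what is new or still open speak of the compounds shown alone.

Three measured compounds share one core and differ only in the aryl group on the amide-type nitrogen. In a functional assay on MGC-803 cells (Homo sapiens) for inhibition, read by MTT assay, with a stated time of 72 h (a higher number here means a weaker inhibitor, a lower number a stronger inhibitor), compound 1 `O=C(CSc1nc(Nc2ccccc2)c2ccccc2n1)Nc1ccccc1Br` gives 18600 nM. Within the data shown here, compound 2 `C=CC(=O)Nc1cccc(NC(=O)CSc2nc(Nc3ccccc3)c3ccccc3n2)c1` gives 7310 nM in this assay, the lowest of the two numbers known, with compound 1 as its nearest neighbour. Compound 3 `O=C(CSc1nc(Nc2ccccc2)c2ccccc2n1)Nc1ccc([N+](=O)[O-])cc1` reaches only a limit of this assay, > 50000 nM, so no number is known for it. This is the limit of > 50000 nM in this assay, at which 1 of the 3 values shown sits.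

The measured steps are all exchanges of that aryl group: a 2.5-fold lower number from compound 1 to compound 2 (0.41 log units; beyond the scatter), an at least 2.6-fold higher number from compound 1 to compound 3 (0.42 log units; beyond the scatter) and an at least 6.8-fold higher number from compound 2 to compound 3 (0.83 log units; beyond the scatter).

Compound 4 `C=CC(=O)Nc1cccc(NC(=O)CSc2nc(Nc3ccccc3Cl)c3ccccc3n2)c1` keeps the group of compound 2 on the amide-type nitrogen and differs from it elsewhere: chloro in place of hydrogen on an aromatic carbon. Among the measured compounds shown here, none of the measured steps changes this part of the molecule, so none bears directly on the new step, and no measured exchange of the same kind exists here. The expectation therefore is a step of no size beyond the scatter, a 1.0-fold lower number from compound 2 to compound 4 (0.00 log units; within the scatter), in this assay. For compound 4 the estimated value in this assay is 7300 nM, expected to lie between 2800 nM and 19000 nM.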

Compound 4, half-maximal inhibitory concentration: 20700 nM
Beside the measured number, compound 4's estimate is 2.8-fold (0.45 log units) below it, and the stated range ends below it.
By their numbers in this assay, from the lowest: compound 2; then compounds 1 and 4 (each within the scatter of the next). At a limit, above all of these: compound 3.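

In this assay, chloro in place of hydrogen on an aromatic carbon of the anilino ring, ortho to a large group, gives a 2.8-fold higher number from compound 2 to compound 4 (0.45 log units; beyond the scatter), so inhibition is weaker with this change. The earlier compounds shown here varied only the aryl group on the amide-type nitrogen, whereas this step shows that the other end of the molecule also affects the result: adding a single heavy atom to the anilino ring, while the rest of compound 2 stays the same, moves the number beyond the usual scatter. Nothing measured here explains why this step goes in this direction or has this size.

The compounds shown leave open whether the loss is specific to chloro or would also appear with another group at this place, such as fluoro, methyl, methoxy or an amine, and whether chloro on a different carbon of the same ring would give a similar result. From the compounds shown here alone, it also remains open whether the change would have the same effect with another group on the amide-type nitrogen, such as the 2-bromophenyl of compound 1.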